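Swapping a phenyl for propyl on the alkyne chain

The compounds below may be only part of what the source reports. "The series", "measured", "known", "first", "only" and "open" are said of these compounds alone.

Compound 1 `CCCCC#Cc1cn(C/C=C\CN2C(=O)c3ccccc3C2=O)c(=O)[nH]c1=O` gives 41000 nM. Compound 2 `O=C1c2ccccc2C(=O)N1C/C=C\Cn1cc(C#CCCc2ccccc2)c(=O)[nH]c1=O` gives 146000 nM. Compound 3 `O=C1c2ccccc2C(=O)N1C/C=C/Cn1cc(C#CCCc2ccccc2)c(=O)[nH]c1=O` gives 39000 nM.

These three values come from a functional assay on MOLT-4 cells (Homo sapiens) for antiproliferative activity, read by MTT assay, with a stated time of 3 days; a higher number here means a weaker inhibitor, a lower number a stronger inhibitor. Compound 3 has the lowest of the three numbers, but its value is within the usual scatter of that of compound 1, so the two cannot be told apart; only compound 2 is clearly separated.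

Compound 4 `CCCCCC#Cc1cn(C/C=C/CN2C(=O)c3ccccc3C2=O)c(=O)[nH]c1=O` has not yet been measured. It differs from compound 3 by propyl in place of phenyl on a saturated chain carbon, two bonds along the chain from a triple-bonded carbon. The measured step that bears most closely on this is a 3.6-fold higher number from compound 1 to compound 2 (0.55 log units; beyond the scatter), where placing a phenyl on that chain carbon raised the number. Compound 4 reverses that kind of change, though with propyl rather than ethyl, and does so in the series where the double bond is drawn E, as in compound 3, whereas the earlier step was seen in the Z series. The step of a 3.7-fold lower number from compound 2 to compound 3 (0.57 log units; beyond the scatter) shows that the drawn configuration also matters, because of the fact that compounds 2 and 3 differ only in the configuration as drawn.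

Compound 4 is therefore expected to show a lower number than compound 3, by about a 2.8-fold lower number from compound 3 to compound 4 (0.44 log units; beyond the scatter). The estimate for compound 4 is 14000 nM, within a range from 5000 nM to 40000 nM.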

Compound 4, half-maximal inhibitory concentration: > 500000 nM
Compound 4: no number, only a limit; the forecaster's own chance of this, stated with the estimate: 5%; middle value at least 35-fold (1.55 log units) away from the limit.
By their numbers in this assay, from the lowest: compounds 3 and 1 (each within the scatter of the next); then compound 2. At a limit, above all of these: compound 4.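

In this assay compound 4 gives > 500000 nM, which is a limit of the assay and not a number. Even so, the step can be read as an at least 12-fold higher number from compound 3 to compound 4 (1.10 log units; beyond the scatter), so with the double bond drawn E, phenyl on this saturated chain carbon goes with the lower number and propyl with the higher one. That runs opposite to the Z series, where phenyl in place of ethyl gave a 3.6-fold higher number from compound 1 to compound 2 (0.55 log units; beyond the scatter), so the direction of a change at this position does not carry over from one series to the other.

The compounds shown cannot separate the role of the drawn double bond from that of propyl standing where ethyl stood in the earlier step. Going by these compounds, how an amine, a carboxylic acid or a longer chain would behave on this chain carbon also remains open.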